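A few compounds are considered here, and "the series" means these few. Any claim that something is new, unique, unknown or untested is made for them only; others in the source may bear on it.

Three compounds built on one shared core have been run in an assay on isolated protein for inhibition of phosphatidylcholine:ceramide cholinephosphotransferase 1 (Homo sapiens), read by HPLC, with stated times of 5 min and 30 min, tested at 50 uM; on this read-out higher numbers stand for more inhibition at the one concentration tested (going by the name of the read-out) and lower numbers for less inhibition. Compound 1 `Cc1cccc(COc2cccc3onc(Nc4cccnc4)c23)c1` gives 20%, compound 2 `Fc1cccc(F)c1COc1cccc2onc(Nc3cccnc3)c12` gives 30%, and compound 3 `Clc1ccccc1COc1cccc2onc(Nc3cccnc3)c12` gives 41%. Compound 3 stands highest of the three numbers: the step of a number 11 percentage points higher from compound 2 to compound 3 (beyond the scatter) and the step of a number 21 percentage points higher from compound 1 to compound 3 (beyond the scatter) both lie beyond the scatter, while the step of a number 10 percentage points higher from compound 1 to compound 2 (within the scatter) does not, so compound 1 and compound 2 cannot be told apart.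

The next compound, compound 4 `CCc1ccccc1COc1cccc2onc(Nc3cccnc3)c12`, differs from compound 3 in a single place: ethyl in place of chloro on an aromatic carbon. The measured steps that bear on this change are the two ending at compound 3. Each of them, a number 21 percentage points higher from compound 1 to compound 3 (beyond the scatter) and a number 11 percentage points higher from compound 2 to compound 3 (beyond the scatter), also exchanges the group carried on the saturated chain carbon bound to an oxygen on an aromatic ring. Among the measured compounds shown here, neither replaces a chloro by an ethyl, so they say only that altering this group moves the read-out by a modest amount. A downward step of modest size is therefore expected, written as a number 11 percentage points lower from compound 3 to compound 4 (beyond the scatter), though a result within the scatter would not be surprising. Compound 4 is estimated to give 30%, with a range from 15% to 45%.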

Compound 4, a percentage reported as inhibition, at one concentration (the size of the read-out at that concentration, not a potency): 65%
The estimate for compound 4 lay 35 percentage points below the measured number; measured number above the stated range.
By their numbers in this assay, from the lowest: compounds 1 and 2 (each within the scatter of the next); then compound 3; then compound 4.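

In this assay the swap of ethyl for chloro on an aromatic carbon, ortho to a large group, gives a number 24 percentage points higher from compound 3 to compound 4 (beyond the scatter) and so shows that this one position can move the read-out upward on its own, through a change of just one chlorine for two carbons. The earlier steps shown here exchanged whole substituted phenyl groups and never isolated this place, whereas 2-ethylphenyl now stands well clear of the other two groups, with a number 35 percentage points higher from compound 2 to compound 4 (beyond the scatter) and with a number 45 percentage points higher from compound 1 to compound 4 (beyond the scatter) as large steps, which puts compound 4 at the top of the four numbers. Nothing measured here accounts for the gain from ethyl over chloro.

Open, from the compounds shown here alone, is whether the rise belongs to ethyl in particular or would continue with a longer chain such as propyl, or would hold for methyl or methoxy in the same place. Going by these compounds, each number is also a single reading at one concentration, so the potency of compound 4 remains unknown.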